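Methoxy to hydroxy, repeated on the second core

The compounds below may be only part of what the source reports. "The series", "measured", "known", "first", "only" and "open" are said of these compounds alone.

Compound 1 `COc1ccc(/C=C/C(=O)c2ccccc2-c2ccc(F)cc2)cc1OC` and compound 3 `COc1ccc(C(=O)/C=C/c2ccccc2-c2ccc(F)cc2)cc1OC` are built from the same atoms joined differently; the difference between the two cores is not broken down here. In a functional assay on A549 cells (Homo sapiens) for antiproliferative activity, read by sulforhodamine B assay, with a stated time of 48 h (a lower number here means a stronger inhibitor, a higher number a weaker inhibitor), compound 1 gives 440 nM, while compound 3 gives 7500 nM, a number beyond the scatter from that of compound 1.

Compound 2 `COc1cc(/C=C/C(=O)c2ccccc2-c2ccc(F)cc2)ccc1O` carries on the core of compound 1 the change (hydrogen in place of methyl on an oxygen on an aromatic ring). In this assay compound 2 gives 7600 nM, so the step is a 17-fold higher number from compound 1 to compound 2 (1.24 log units; beyond the scatter). Compound 2 and compound 3 read within the scatter of each other.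

Compound 4 `COc1cc(C(=O)/C=C/c2ccccc2-c2ccc(F)cc2)ccc1O`, not yet measured, carries on the core of compound 3 the change (hydrogen in place of methyl on an oxygen on an aromatic ring). Going by the values given here, the change is the same as the one made from compound 1 to compound 2, at the same place, so this is its second instance; only the one measured instance is available to judge it by.

The expectation for compound 4 rests on that single measured step, a 17-fold higher number from compound 1 to compound 2 (1.24 log units; beyond the scatter), applied to the value of compound 3, 7500 nM. The expected step is an 8.0-fold higher number from compound 3 to compound 4 (0.90 log units; beyond the scatter), carried over from the first core without adjustment. Because compound 3 is already weak at 7500 nM, the expected number for compound 4 is a high one, and the uncertainty around it is wide. Compound 4 is expected to give 60000 nM in this assay, with the estimate spanning 15000 nM to 200000 nM.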

Compound 4, half-maximal inhibitory concentration: 4600 nM
The estimate for compound 4 lay 13-fold (1.12 log units) above the measured number, outside the stated range (below it).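

On the core of compound 3, methoxy to hydroxy reads as a 1.6-fold lower number from compound 3 to compound 4 (0.21 log units; within the scatter) in this assay, whereas the same change on the core of compound 1 reads as a 17-fold higher number from compound 1 to compound 2 (1.24 log units; beyond the scatter). The change therefore does not carry over as a fixed step between these two cores, and the two instances differ by more than the scatter allows: the same change on two cores in this assay, a 17-fold higher number (1.24 log units; beyond the scatter) from compound 1 to compound 2 and a 1.6-fold lower number (0.21 log units; within the scatter) from compound 3 to compound 4, 28-fold (1.45 log units) apart, beyond the scatter of two such steps

Going by these compounds alone, this shows that, in these four compounds, the size of the step depends on the core that carries it, but with only one matched pair per core it does not show which feature of the cores sets the difference, nor what the change would do on a third core.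

Open, going by these compounds, is whether a longer chain on that oxygen, such as ethoxy, or an amine in place of the hydroxy, would follow the pattern of the core of compound 1 or that of the core of compound 3. Also open, on these data alone, is whether the contrast between the two cores would persist with a group other than the fluorine on the shared aromatic ring, such as chlorine or methyl.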